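Working notes: compound 1 to compound 4, cytotoxicity

The compounds below may be only part of what the source reports. "The series", "measured", "known", "first", "only" and "open" are said of these compounds alone.

Measured so far:
compound 1 `Fc1ccc(Cc2ccc3c(NCCCNCc4ccco4)ccnc3c2)c(Cl)c1` — 5730 nM
compound 2 `COc1ccc(F)cc1CNCCCNc1ccnc2cc(Cc3ccc(F)cc3Cl)ccc12` — 2460 nM
compound 3 `COc1cccc(CNCCCNc2ccnc3cc(Oc4cccc(N(C)C)c4)ccc23)c1O` — 7300 nM

In an ADME assay on HepG2 cells (Homo sapiens) for cytotoxicity, read by luminescence, CellTiter-Glo and ATP content, with a stated time of 72 h (a higher number here means that more compound is needed for the effect, a lower number that less compound is needed), compound 1 gives the second highest of the three numbers. Compound 3 sits nearest to it, within the scatter. Going by the values given here, the only step measured so far, a 2.3-fold lower number from compound 1 to compound 2 (0.37 log units; beyond the scatter), concerns the aryl group on the chain carbon bound to the amine nitrogen, not the benzyl ring.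

Compound 4 `Fc1ccc(Cc2ccc3c(NCCCNCc4ccco4)ccnc3c2)cc1` differs from compound 1 by hydrogen in place of chloro on an aromatic carbon. Among the compounds with values here, no measured step touches this position, so the data give no direction for the change; the step is expected to stay within the scatter, estimated as a 1.2-fold higher number from compound 1 to compound 4 (0.09 log units; within the scatter). Compound 4 is therefore expected to give about 7000 nM in this assay, with a range of 3000 nM to 16000 nM.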

Compound 4, half-maximal effective concentration: 5600 nM
For compound 4 the middle estimate is 1.3-fold (0.10 log units) above the measured one; the measured number falls inside the stated range.
By their numbers in this assay, from the lowest: compound 2; then compounds 4, 1 and 3 (each within the scatter of the next).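

In this assay, the change from 2-chloro-4-fluorobenzyl to 4-fluorobenzyl gives a 1.0-fold lower number from compound 1 to compound 4 (0.01 log units; within the scatter), the first step read at this position. With the furan-2-yl end held fixed, this pair shows that the chloro group can be replaced by hydrogen without a step beyond the scatter. No measured evidence bears on this result.

From the compounds shown here alone, whether a methoxy or trifluoromethyl group at this place would also stay within the scatter remains open. So does whether the same change would hold with the 5-fluoro-2-methoxyphenyl end of compound 2.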